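Furan-2-yl for thiophen-2-yl on a topoisomerase 1 inhibitor

The compounds below may be only part of what the source reports. "The series", "measured", "known", "first", "only" and "open" are said of these compounds alone.

Measured in an assay on isolated protein for inhibition of DNA topoisomerase 1 (Homo sapiens), with a stated time of 30 min, tested at 100 uM; a lower number here means a weaker effect, a higher number a stronger effect of the compound at the concentration tested:
Compound 1 `Oc1ccc(-c2cc(-c3cccs3)cc(-c3ccccc3O)n2)cc1`: 72.2%
Compound 2 `Oc1ccc(-c2cc(-c3cccs3)cc(-c3ccc(O)cc3)n2)cc1`: 86.3%

Compound 1 stands lowest of the two numbers; compound 2 lies above it by a number 14.1 percentage points higher from compound 1 to compound 2 (beyond the scatter). Compound 3 `Oc1ccc(-c2cc(-c3ccco3)cc(-c3ccccc3O)n2)cc1` differs from compound 1 at another place: furan-2-yl in place of thiophen-2-yl on an aromatic carbon. Among the measured compounds shown here, no measured step touches this change; the only step known, a number 14.1 percentage points higher from compound 1 to compound 2 (beyond the scatter), concerns the hydroxyphenyl group and says nothing about the five-membered ring. Without a guide, the expected step is none beyond the scatter, a number 2.2 percentage points lower from compound 1 to compound 3 (within the scatter). Compound 3 is therefore estimated at 70%, within 50% to 85%.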

Compound 3, a percentage reported as inhibition, at one concentration (the size of the read-out at that concentration, not a potency): 83%
Beside the measured number, compound 3's estimate is 13 percentage points below it, within the range that was stated.
By their numbers in this assay, from the lowest: compound 1; then compounds 3 and 2 (each within the scatter of the next).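

The place opposite the ring nitrogen also matters: until now, only a change in the hydroxyphenyl group had been seen to shift the result. In this assay the furan-2-yl group in place of thiophen-2-yl gives a number 10.8 percentage points higher from compound 1 to compound 3 (beyond the scatter) even though only the hetero atom of the five-membered ring differs, oxygen for sulfur. Nothing available explains this gain.

On these data alone, whether a plain phenyl ring or an amine at this place would hold the read-out remains open. So does whether furan-2-yl would give a similar step on compound 2.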